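The source may report more compounds than this note shows. Statements on the series, on what has been measured and on what is new or still open speak of the compounds shown alone.

Working notes on the series. Compound 1 `CCOC(=O)c1cccc(-c2ccc(N(C)C)cc2)c1` gives 40000 nM in an assay on COS-7 cells for inhibition of patatin-like phospholipase domain-containing protein 2 (Mus musculus); on this read-out higher numbers stand for weaker inhibition and lower numbers for stronger inhibition. Compound 2 `CN(C)c1ccc(-c2cccc([N+](=O)[O-])c2)cc1` gives in this assay only a limit, > 200000 nM, as recorded in the limit of > 200000 nM in this assay, at which 1 of the 3 values shown sits. Compound 3 `CCOC(=O)Nc1cccc(-c2ccc(N(C)C)cc2)c1` gives 3000 nM in this assay, the lowest number among the values given; the nearest number is that of compound 1, and the step between them is a 13-fold lower number from compound 1 to compound 3 (1.12 log units; beyond the scatter). The other steps are an at least 5.0-fold higher number from compound 1 to compound 2 (0.69 log units; beyond the scatter) and an at least 66-fold lower number from compound 2 to compound 3 (1.82 log units; beyond the scatter).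

Compound 4 `CC(C)OC(=O)Nc1cccc(-c2ccc(N(C)C)cc2)c1` differs from compound 3 by methyl in place of hydrogen on a saturated chain carbon bound to an oxygen next to a carbonyl group and a saturated chain carbon. Among the compounds with values here, every measured step changes the group on the aromatic carbon, while the ethoxycarbonyl part of the carbamate stays the same in compound 1 and compound 3; no measured step touches the chain carbon that changes here. The change is therefore expected to move the number in this assay by no more than the scatter, a step of no change at the digits printed from compound 3 to compound 4 (within the scatter). For compound 4 the estimate in this assay is 3000 nM, within a range from 1000 nM to 9000 nM.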

Compound 4, half-maximal inhibitory concentration: 82000 nM
Estimate against measurement, compound 4: 27-fold (1.44 log units) below, outside the stated range (above it).
By their numbers in this assay, from the lowest: compound 3; then compound 1; then compound 4. At a limit, above all of these: compound 2.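

The saturated chain carbon bound to the oxygen is not a silent position in this assay: going from ethoxy to isopropoxy, a single added methyl, gives a 27-fold higher number from compound 3 to compound 4 (1.44 log units; beyond the scatter), so the far end of the carbamate matters as well as the group on the aromatic carbon. Against ethoxycarbonyl, (isopropoxycarbonyl)amino reads a 2.1-fold higher number from compound 1 to compound 4 (0.31 log units; beyond the scatter), so the gain seen with (ethoxycarbonyl)amino is lost and slightly reversed with this one methyl. Compound 2 stands only at a limit, and an at least 2.4-fold lower number from compound 2 to compound 4 (0.38 log units; beyond the scatter) can be read as a bound only: the limit of > 200000 nM in this assay, at which 1 of the 4 values shown sits.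

As far as these compounds go, with only ethoxy and isopropoxy at this place, the number for a methoxy, a propoxy or a tert-butoxy group there stays open. Also open is why one methyl moves the number this far.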